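Turning the ester of compound 2 into an acid

A few compounds are considered here, and "the series" means these few. Any claim that something is new, unique, unknown or untested is made for them only; others in the source may bear on it.

Compound 1 `C=CCN(C)C(=O)c1ccc(C(CC)(CC)c2ccc(OCCC(O)(CC)CC)c(C)c2)n1CC`: > 50000 nM (a limit of the assay)
Compound 2 `CCOC(=O)CN(C)C(=O)c1ccc(C(CC)(CC)c2ccc(OCCC(O)(CC)CC)c(C)c2)n1CC`: 3210 nM

Both results come from a functional assay on MCF7 cells (Homo sapiens) for antiproliferative activity, read by MTT assay, with a stated time of 48 h; a lower number here means a stronger inhibitor, a higher number a weaker inhibitor. Compound 1 gives > 50000 nM, which is a limit and not a number. Among the measured compounds shown here, compound 2, at 3210 nM, therefore holds the only true number so far, so there is no series to rank it in.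

The next compound, compound 3 `CCn1c(C(=O)N(C)CC(=O)O)ccc1C(CC)(CC)c1ccc(OCCC(O)(CC)CC)c(C)c1`, has not yet been measured. It carries hydrogen in place of ethyl on an oxygen next to a carbonyl group, so ethoxycarbonyl becomes carboxy: hydrogen in place of ethyl on an oxygen next to a carbonyl group.

For the measured compounds named here, one measured step bears on this change. It is an at least 15-fold lower number from compound 1 to compound 2 (1.19 log units; beyond the scatter), a large step that brought in the very ethoxycarbonyl now being altered. Going by that step alone, this end of the molecule can matter a great deal, and altering the group that came with the gain is expected to give back part of it. A moderate move to a higher number in this assay is therefore expected, though the direction is uncertain. The expected change is a 2.5-fold higher number from compound 2 to compound 3 (0.40 log units; beyond the scatter). For compound 3 the estimated value is 8000 nM, with an expected range from 1500 nM to 40000 nM.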

Compound 3, half-maximal inhibitory concentration: 79 nM
The estimate for compound 3 lay 100-fold (2.01 log units) above the measured number; the whole stated range lies above it.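

Replacing ethyl with hydrogen on the oxygen next to the carbonyl group, which turns ethoxycarbonyl into carboxy, gives a 41-fold lower number from compound 2 to compound 3 (1.61 log units; beyond the scatter) in this assay. The earlier step showed only that this end of the molecule can matter; this one shows that the ethyl is not needed for the gain, and that carboxymethyl does far better here than (ethoxycarbonyl)methyl. Set against the vinyl end, carboxy gives an at least 630-fold lower number from compound 1 to compound 3 (2.80 log units; beyond the scatter), and the starting point of that step is a limit of the assay and not a number: the limit of > 50000 nM in this assay, at which 1 of the 3 values shown sits.

The compounds shown leave open whether a primary amide or a methyl ester at this end would keep the number as low, and whether a longer chain carrying the carboxylic acid would do the same. Nor can these three compounds say why removing the ethyl has so large an effect on the cells.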